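This account rests on a few compounds, and the source may have more. Where it says the series, first, only, none or still open, it means among the compounds named here.

Compound 2 `COc1cc(-n2cnc3ccc(-c4ccccc4Cl)cc32)cc(OC)c1OC` was tested in a functional assay on A549 cells (Homo sapiens) for antiproliferative activity, read by MTT assay, with a stated time of 72 h; on this read-out lower numbers stand for stronger inhibition and higher numbers for weaker inhibition. Compound 2 gives > 10000 nM, which is a limit of the assay rather than a number. Compound 1 `COc1ccc(-c2ccc3ncn(-c4cc(OC)c(OC)c(OC)c4)c3c2)cc1` likewise gives > 10000 nM, also a limit. Among the compounds with values here, the only measured step, a step that the two limits leave unreadable from compound 1 to compound 2, therefore cannot be sized, and the limit of > 10000 nM in this assay, at which 2 of the 2 values shown sit, is all the data show. Compound 3 `COc1cc(-n2cnc3ccc(-c4cccc(C)c4)cc32)cc(OC)c1OC` carries 3-methylphenyl in place of 2-chlorophenyl on an aromatic carbon. Within the data shown here, no measured step bears on this change, so the expectation rests on the two limits alone. Compound 3 is expected to show a step that the limit leaves unreadable from compound 2 to compound 3, most likely remaining at the limit. Compound 3 is estimated at 20000 nM, within 5000 nM to 80000 nM.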

Compound 3, half-maximal inhibitory concentration: 3820 nM
Estimate against measurement, compound 3: 5.2-fold (0.72 log units) above, outside the stated range (below it).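

In this assay, the group on this aromatic carbon can bring the shared core off the limit: 3-methylphenyl gives an at least 2.6-fold lower number from compound 2 to compound 3 (0.41 log units; beyond the scatter), and an at least 2.6-fold lower number from compound 1 to compound 3 (0.41 log units; beyond the scatter). Within the data shown here, the choice of group here therefore matters, which the earlier compounds alone could not show. Both steps are only minimum sizes, as each starts from a limit: the limit of > 10000 nM in this assay, at which 2 of the 3 values shown sit.

Going by these compounds, whether the methyl group itself or its place on the phenyl ring drives the gain stays open. On these data alone, how an amine or a carboxylic acid would read on this ring also remains unknown.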